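Series notes: trifluoromethyl added to the phenyl

The source may report more compounds than this note shows. Statements on the series, on what has been measured and on what is new or still open speak of the compounds shown alone.

Measured so far:
- compound 1 `CCOC(=O)C1=Cc2ccccc2OC1(OCc1cn(-c2ccccc2)nn1)C(F)(F)F`: in a functional assay on A549 cells (Homo sapiens) for inhibition, read by MTT assay, with a stated time of 24 h (a lower number here means a stronger inhibitor, a higher number a weaker inhibitor), compound 1 gives only a limit, > 150000 nM.
- compound 2 `CCOC(=O)C1=Cc2ccccc2OC1(OCc1cc(-c2ccc(OC)cc2)no1)C(F)(F)F`: in this assay compound 2 likewise gives only a limit, > 150000 nM.

Compound 1 therefore stands at the limit of this assay, with no number of its own; the other value shown is a limit too, and both sit at the limit of > 150000 nM in this assay, at which 2 of the 2 values shown sit. Among the measured compounds shown here, no step between measured compounds can be drawn from this.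

Compound 3 `CCOC(=O)C1=Cc2ccccc2OC1(OCc1cn(-c2cccc(C(F)(F)F)c2)nn1)C(F)(F)F` differs from compound 1 by trifluoromethyl in place of hydrogen on an aromatic carbon, in words: trifluoromethyl in place of hydrogen on an aromatic carbon, the phenyl becoming 3-(trifluoromethyl)phenyl. With compound 1 and compound 2 both at the limit, no size or direction of step in this assay can be supported, and none beyond the scatter is expected. For compound 3 the expected result is again a limit, estimated at 150000 nM with a range of 60000 nM to 300000 nM. The step of a number no higher from compound 1 to compound 3 (the limit leaves the size open) is thus expected to be nil.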

Compound 3, half-maximal inhibitory concentration: > 150000 nM
Compound 3 ended at the assay's limit (the forecaster's own chance of this, stated with the estimate: 80%); the middle value lies on the limit itself.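

Among the compounds shown here, no step from compound 1 to compound 3 can be read in this assay as both values are limits, as is that of compound 2: the limit of > 150000 nM in this assay, at which 3 of the 3 values shown sit. Open in this assay is whether any change to the shared core gives a number rather than a limit.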